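Cyclopentyl in place of a branched chain

A few compounds are considered here, and "the series" means these few. Any claim that something is new, unique, unknown or untested is made for them only; others in the source may bear on it.

Measured so far:
compound 1 `CC(C)C(C)/N=C(\NC#N)Nc1cc(C(F)(F)F)cc(C(F)(F)F)c1` — 5500 nM
compound 2 `C[C@@H](/N=C(\NC#N)Nc1cc(C(F)(F)F)cc(C(F)(F)F)c1)C(C)(C)C` — 18000 nM

In a functional assay on Beta-TC3 cells (Rattus norvegicus) with Beta-TC3 (Mus musculus) as the target, using a membrane potential dye (on this read-out lower numbers stand for stronger inhibition and higher numbers for weaker inhibition), compound 2 gives 18000 nM, the highest of the two numbers measured; the nearest is compound 1, which gives 5500 nM. Compound 3 `N#CN/C(=N\C1CCCC1)Nc1cc(C(F)(F)F)cc(C(F)(F)F)c1` is obtained from compound 2 by the change (cyclopentyl in place of 1,2,2-trimethylpropyl on a double-bonded nitrogen). For the measured compounds named here, the only measured step that touches this position is a 3.3-fold higher number from compound 1 to compound 2 (0.51 log units; beyond the scatter), where one branched chain replaced another. Going by the values given here, no measured step exchanges a chain for a ring, so the bearing of that step on compound 3 is indirect. Because a 3.3-fold higher number from compound 1 to compound 2 (0.51 log units; beyond the scatter) places compound 2 at the weak end of the two, a return toward the number of compound 1, or somewhat past it, is the expectation for compound 3, giving a 3.0-fold lower number from compound 2 to compound 3 (0.48 log units; beyond the scatter). The estimate for compound 3 in this assay is therefore 6000 nM, within a range from 2000 nM to 20000 nM.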

Compound 3, half-maximal inhibitory concentration: 4700 nM
For compound 3 the middle estimate is 1.3-fold (0.11 log units) above the measured one, and the stated range covers the measured number.
By their numbers in this assay, from the lowest: compounds 3 and 1 (each within the scatter of the next); then compound 2.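

In this assay, exchanging 1,2,2-trimethylpropyl for cyclopentyl on the double-bonded nitrogen gives a 3.8-fold lower number from compound 2 to compound 3 (0.58 log units; beyond the scatter), the first sign that this position accepts a ring of carbon only and not just a branched chain. Against 1,2-dimethylpropyl the same ring gives a 1.2-fold lower number from compound 1 to compound 3 (0.07 log units; within the scatter), so these two groups cannot be told apart here, and among the three compounds only the 1,2,2-trimethylpropyl of compound 2 stands out, on the weak side. No measurement here explains why the numbers fall this way.

Going by these compounds, whether a larger ring such as cyclohexyl, a ring carrying an amine, or a straight chain such as n-butyl would move the number remains open. On these data alone, all three compounds share one core, so how this position behaves with any other change to that core is also open.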